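This account rests on a few compounds, and the source may have more. Where it says the series, first, only, none or still open, it means among the compounds named here.

Within the data shown here, in a functional assay on the whole organism for inhibition, with Mus musculus as the target (a higher number here means that more compound is needed for the effect, a lower number that less compound is needed), compound 2 `CCCCOC(=O)Nc1cccc2c1CN(C)CC2c1ccccc1` gives 4 mg/kg, the only real number available so far. Its close relative, compound 1 `CCCNC(=O)Nc1cccc2c1CN(C)CC2c1ccccc1`, is reported as > 80 mg/kg. That entry is a limit of the assay and not a number.

The next compound, compound 3 `CCCCNCC(=O)Nc1cccc2c1CN(C)CC2c1ccccc1`, keeps the shared core but carries (butylamino)methyl in place of butoxy on a carbonyl carbon. Among the measured compounds shown here, only one measured step bears on this change, and it is a large one: an at least 20-fold lower number from compound 1 to compound 2 (1.30 log units; beyond the scatter). That step shows that the group on this carbonyl carbon can matter greatly in this assay. Compound 3 gives up the butoxy group that came in with that step, and like the propylamino group of compound 1, its new group contains an amine nitrogen. A single step is thin evidence, however, and (butylamino)methyl is not propylamino, so only part of that loss is expected to return. A sizeable move towards a higher number, meaning more compound needed, is therefore expected, and the estimated step is a 5.0-fold higher number from compound 2 to compound 3 (0.70 log units; beyond the scatter). For compound 3 the estimated value is 20 mg/kg, with an expected range of 5 mg/kg to 80 mg/kg.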

Compound 3, dose for half-maximal effect: 32 mg/kg
Compound 3: middle estimate off by 1.6-fold (0.20 log units), on the low side; the range from low to high includes it.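

In this assay, the change on this carbonyl carbon has a clear cost, with (butylamino)methyl in place of butoxy giving an 8.0-fold higher number from compound 2 to compound 3 (0.90 log units; beyond the scatter), so the gain seen with butoxy does not carry over to this other chain of similar size. At the same time, the second comparison gives an at least 2.5-fold lower number from compound 1 to compound 3 (0.39 log units; beyond the scatter), which shows that a nitrogen-containing group here does not have to behave like propylamino and that this position gives graded results rather than simply high or low values. The size of that second step remains only a bound, since the entry for compound 1 is a limit of the assay and not a number: the limit of > 80 mg/kg in this assay, at which 1 of the 3 values shown sits.

Compound 3 alters both the atom attached to the carbonyl carbon and the atom within the chain, so the compounds shown cannot separate the effects of these two changes. From the compounds shown here alone, it remains open how a plain pentyl group, with only carbon in that chain, or a (dimethylamino)methyl group, with no hydrogen on its amine nitrogen, would compare with butoxy and (butylamino)methyl.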